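Estimating the Cytotoxicity of Compound 4

The source may hold more compounds than are shown below. What is called first, only, known or untested is meant among the compounds shown, and "the series" means these compounds.

Compound 1 `COc1cc(NC(C)CCCNC(=O)/C=C/c2ccccc2F)c2ncccc2c1`: 3500 nM in an ADME assay on L6 cells (Rattus norvegicus) for cytotoxicity, read by resazurin assay, with a stated time of 70 h; a higher number here means a weaker inhibitor, a lower number a stronger inhibitor
Compound 2 `COc1cc(NC(C)CCCNC(=O)/C=C/c2ccc(C(F)(F)F)cc2)c2ncccc2c1`: 160000 nM in this assay
Compound 3 `COc1cc(NC(C)CCCNC(=O)NNC(=O)/C=C/c2ccccc2F)c2ncccc2c1`: 25100 nM in this assay

Of these three numbers, compound 3 stands second highest in this assay: compound 2 gives a higher number and compound 1 a lower one, both differences lying beyond the usual scatter. Compound 4 `COc1cc(NC(C)CCCNC(=O)NNC(=O)Nc2ccc(Br)cc2)c2ncccc2c1` has not been measured yet. It differs from compound 3 in one place: (4-bromophenyl)amino in place of 2-(2-fluorophenyl)ethenyl on a carbonyl carbon.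

Among the compounds with values here, only one measured step is available to guide an expectation, a 46-fold higher number from compound 1 to compound 2 (1.66 log units; beyond the scatter). That step kept the ethenyl chain and changed only the substituted aromatic ring on it, yet it moved the number a long way. Within the data shown here, the change to compound 4 is larger in kind, since the whole 2-(2-fluorophenyl)ethenyl group leaves and a (4-bromophenyl)amino group enters on the carbonyl carbon; no measured pair mirrors that. Given that an exchange of the aromatic group alone already produced a large step, the number for compound 4 is expected to move beyond the scatter as well, more likely upward, though the direction is uncertain. Compound 4 is therefore estimated at 40000 nM, within 8000 nM to 200000 nM, an expected step of a 1.6-fold higher number from compound 3 to compound 4 (0.20 log units; within the scatter).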

Compound 4, half-maximal inhibitory concentration: 38700 nM
The estimate for compound 4 lay 1.0-fold (0.01 log units) above the measured number; the range from low to high includes it.
By their numbers in this assay, from the lowest: compound 1; then compounds 3 and 4 (each within the scatter of the next); then compound 2.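

In this assay, putting (4-bromophenyl)amino in place of 2-(2-fluorophenyl)ethenyl on a carbonyl carbon gives a 1.5-fold higher number from compound 3 to compound 4 (0.19 log units; within the scatter) and so leaves the two compounds indistinguishable, even though the group that enters has a different aromatic ring, has a nitrogen where the leaving group has its double bond, and carries a hydrogen-bond donor that the leaving group lacks. Within the data shown here, this is the first look at a change of the whole group on this carbonyl carbon, and it contrasts with a 46-fold higher number from compound 1 to compound 2 (1.66 log units; beyond the scatter), a large step produced by changing only the aromatic ring on the ethenyl chain, in compounds without the longer linking chain found in compound 3 and compound 4. Among these compounds, nothing available explains why one exchange moves the number so far and the other does not.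

The ring and the atoms joining it to the carbonyl carbon changed together here, so the separate contributions of the bromine, the fluorine and the nitrogen cannot be read from this one pair. Also open, from the compounds shown here alone, is how the number responds on this carbonyl carbon to a group with no aromatic ring, such as a simple amine or a carboxylic acid, or to a longer chain carrying the 4-bromophenyl ring.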